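The source may hold more compounds than are shown below. What is called first, only, known or untested is meant among the compounds shown, and "the series" means these compounds.

Compound 1 `N#Cc1ccc(Nc2nc(Oc3ccnc4ccccc34)nc(N3CCN(C(c4ccccc4)c4ccc(Cl)cc4)CC3)n2)cc1C(F)(F)F` was examined in a functional assay on DU-145 cells (Homo sapiens) for cytotoxicity, read by sulforhodamine B assay, with a stated time of 48 h; on this read-out higher numbers stand for weaker inhibition of growth and lower numbers for stronger inhibition of growth. In this assay compound 1 gives > 100000 nM, which is a limit of the assay rather than a number. Compound 2 `COc1ccc(CN2CCN(c3nc(Nc4ccc(C#N)c(C(F)(F)F)c4)nc(Oc4ccnc5ccccc45)n3)CC2)c(OC)c1OC` shares the same core with a different group on the piperazine nitrogen. In this assay compound 2 gives > 100000 nM, again only a limit. Both values therefore sit at the limit of > 100000 nM in this assay, at which 2 of the 2 values shown sit, so compound 1 stands at the edge of what this assay reports, with no numeric value to place it.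

Compound 3 `N#Cc1ccc(Nc2nc(Oc3ccnc4ccccc34)nc(N3CCN(C(c4ccccc4)c4ccccc4)CC3)n2)cc1C(F)(F)F` differs from compound 1 in one place: hydrogen in place of chloro on an aromatic carbon. Among the compounds with values here, no measured pair shows what this change does here. Compound 3 is expected to stay at or near the limit, with an expected step that the limit leaves unreadable from compound 1 to compound 3. Compound 3 is estimated at 150000 nM, expected to fall between 50000 nM and 500000 nM.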

Compound 3, concentration for total growth inhibition: > 100000 nM
Compound 3: no number, only a limit (the forecaster's own chance of this, stated with the estimate: 80%); the middle value does not contradict the limit.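

In this assay, compound 1 and compound 3 each give only a limit, not a number, so no step can be read for 4-chlorophenyl to phenyl: the limit of > 100000 nM in this assay, at which 3 of the 3 values shown sit.

The compounds shown leave open what change on the piperazine nitrogen, if any, would bring a value within the reach of this assay.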